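Removing a methoxy group: expected effect on cell tolerance

The source may report more compounds than this note shows. Statements on the series, on what has been measured and on what is new or still open speak of the compounds shown alone.

Of the compounds shown here, two built on a shared core have been tested in an ADME assay on MT4 cells (Homo sapiens) for cytotoxicity, read by MTT assay; a lower number here means that less compound is tolerated, a higher number that more compound is tolerated. Compound 1 `O=C(CSc1nnnn1-c1cccc2ccccc12)N/N=C/c1ccco1` reaches only a limit of the assay, reported as > 330000 nM. Within the data shown here, compound 2 `COc1ccc(O)c(/C=N/NC(=O)CSc2nnnn2-c2cccc3ccccc23)c1` gives 4510 nM in this assay, and that is the only actual number among the two values measured. The other value, that of compound 1, is a limit of the assay, namely (the limit of > 330000 nM in this assay, at which 1 of the 2 values shown sits). The step of an at least 73-fold lower number from compound 1 to compound 2 (1.86 log units; beyond the scatter) shows that exchanging the ring on the carbon that carries the double bond to nitrogen changed tolerance greatly.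

Compound 3 `O=C(CSc1nnnn1-c1cccc2ccccc12)N/N=C/c1ccccc1O` differs from compound 2 by hydrogen in place of methoxy on an aromatic carbon. Among the measured compounds shown here, the only measured step, an at least 73-fold lower number from compound 1 to compound 2 (1.86 log units; beyond the scatter), replaced an entire ring, so it bears only loosely on the loss of a methoxy group. No change beyond the scatter is expected, and the estimated step is a 1.3-fold higher number from compound 2 to compound 3 (0.12 log units; within the scatter). Compound 3 is expected to give 6000 nM in this assay, most likely between 2000 nM and 25000 nM.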

Compound 3, half-maximal cytotoxic concentration: 4850 nM
Estimate against measurement, compound 3: 1.2-fold (0.09 log units) above, and the stated range covers the measured number.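

In this assay, taking the methoxy group off the ring leaves the number where it was: a 1.1-fold higher number from compound 2 to compound 3 (0.03 log units; within the scatter). At this place on the ring, para to the hydroxy group, the methoxy group therefore makes no difference that can be told from the scatter, and the large gap to the furan-2-yl compound remains without it: an at least 68-fold lower number from compound 1 to compound 3 (1.83 log units; beyond the scatter). That step has only a lower bound, as the value of compound 1 is a limit of the assay and not a number: the limit of > 330000 nM in this assay, at which 1 of the 3 values shown sits.

As far as these compounds go, it remains open whether an amine or a carboxylic acid in place of the methoxy group would also leave the number unchanged. Also open, from the compounds shown here alone, is whether a plain phenyl ring, without the hydroxy group, would fall near compound 3 or near compound 1.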